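A few compounds are considered here, and "the series" means these few. Any claim that something is new, unique, unknown or untested is made for them only; others in the source may bear on it.

The compounds here share the core of compound 1 `CCn1ccnc1-c1cc(OC)c(OC)c(OC)c1`, a five-membered aromatic ring with two nitrogens that carries a trimethoxyphenyl group and, on one nitrogen, a variable substituent. In a functional assay on T47D cells (Homo sapiens) for antiproliferative activity, read by MTT assay, with a stated time of 72 h (on this read-out lower numbers stand for stronger inhibition and higher numbers for weaker inhibition), compound 1 gives > 100000 nM, which is a limit of the assay rather than a number. Compound 2 `COc1cc(-c2nccn2S(=O)(=O)c2ccccc2)cc(OC)c1OC` in this assay likewise gives > 100000 nM, again only a limit. Going by the values given here, compound 3 `COc1cc(-c2nccn2-c2ccc3cc[nH]c3c2)cc(OC)c1OC` in this assay gives 18000 nM, the one number in this set. So compound 1 stands at the limit of > 100000 nM in this assay, at which 2 of the 3 values shown sit; it shows no measurable activity, while compound 3 does.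

Compound 4 `COc1cccc(-n2ccnc2-c2cc(OC)c(OC)c(OC)c2)c1` differs from compound 1 by 3-methoxyphenyl in place of ethyl on an aromatic nitrogen. Among the compounds with values here, no pair of measured compounds shows this exact step. Still, a gain in potency is expected from compound 1 to compound 4, because compound 3 gives 18000 nM with an aromatic group on that nitrogen. The expected step from compound 1 to compound 4 is an at least 10-fold lower number from compound 1 to compound 4 (1.00 log units; beyond the scatter). For compound 4 the estimated value is 10000 nM, within a range from 1500 nM to 70000 nM.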

Compound 4, half-maximal inhibitory concentration: 32200 nM
For compound 4 the middle estimate is 3.2-fold (0.51 log units) below the measured one, and the stated range covers the measured number.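

Putting 3-methoxyphenyl in place of ethyl on this aromatic nitrogen moves the series from no measurable activity to a measurable number in this assay, a change read as an at least 3.1-fold lower number from compound 1 to compound 4 (0.49 log units; beyond the scatter) in this comparison. The size of this step is only a lower bound, since the value of compound 1 is a limit and not a number: the limit of > 100000 nM in this assay, at which 2 of the 4 values shown sit. Compound 4 also gives a second measured compound in this set, and like compound 3 it carries an aromatic ring directly on that nitrogen.

From the compounds shown here alone, what stays open is whether the ring alone accounts for the gain or whether its methoxy group contributes. A plain phenyl, a phenyl bearing an amine or a carboxylic acid, or a longer chain such as butyl would each test a different part of this question.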